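Adding a chloro group to compound 2

The source may report more compounds than this note shows. Statements on the series, on what has been measured and on what is new or still open speak of the compounds shown alone.

In a functional assay on HT-29 cells (Homo sapiens) for inhibition, read by sulforhodamine B assay, with a stated time of 48 h (a higher number here means a weaker inhibitor of growth, a lower number a stronger inhibitor of growth), compound 1 (`NC(=O)c1cc(Br)ccc1NC(=O)/C=C/c1ccccc1`) gives 527 nM and compound 2 (`NC(=O)c1cc(I)ccc1NC(=O)/C=C/c1ccccc1`) gives 367 nM. Among the compounds with values here, compound 2 therefore stands level with compound 1, since the only measured step, a 1.4-fold lower number from compound 1 to compound 2 (0.16 log units; within the scatter), swaps bromo for iodo and lies within the scatter. Compound 3 (`NC(=O)c1cc(I)ccc1NC(=O)/C=C/c1ccccc1Cl`) has chloro in place of hydrogen on an aromatic carbon, ortho to a large group: chloro in place of hydrogen on an aromatic carbon. That measured step changed a different place, so it offers little guidance, and no shift beyond the scatter is expected in either direction. The expected change is a 1.1-fold higher number from compound 2 to compound 3 (0.04 log units; within the scatter). For compound 3 the estimated value is 400 nM, with a range of 130 nM to 1200 nM.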

Compound 3, concentration for 50% growth inhibition: 376 nM
The estimate for compound 3 lay 1.1-fold (0.03 log units) above the measured number; low and high end bracket the measured number.
By their numbers in this assay, from the lowest: compounds 2, 3 and 1 (each within the scatter of the next).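

In this assay the change from phenyl to 2-chlorophenyl gives a 1.0-fold higher number from compound 2 to compound 3 (0.01 log units; within the scatter) and so leaves compound 2 and compound 3 impossible to tell apart. The earlier step concerned the bromo and iodo site, whereas this one shows that chloro is tolerated at a second site, on an aromatic carbon ortho to a large group, with growth inhibition kept in the same range. No measurement given here offers an explanation for this result. From the compounds shown here alone, whether a methoxy group, an amine or a carboxylic acid at this place would separate from compound 2 remains open.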